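Swapping an amide arm for a small ester-like arm

The compounds below may be only part of what the source reports. "The series", "measured", "known", "first", "only" and "open" are said of these compounds alone.

Compound 1, `CCOc1cc(NC(=O)C2(NC(=O)c3ccc4c(C5CCCC5)c(-c5ncc(Cl)cn5)n(C)c4c3)CCC2)ccc1/C=C/C(=O)N[C@@H](CC(=O)O)C(N)=O`, is the reference point. In an ADME assay on stomach for pharmacokinetics, in simulated gastric fluid (on this read-out higher numbers stand for a longer-lived compound and lower numbers for a shorter-lived compound), compound 1 gives > 5 h, which is a limit of the assay rather than a measured number. Two measured relatives replace the (1-carbamoyl-2-carboxyethyl)amino group of compound 1 on the carbonyl carbon: compound 2, `CCOc1cc(NC(=O)C2(NC(=O)c3ccc4c(C5CCCC5)c(-c5ncc(Cl)cn5)n(C)c4c3)CCC2)ccc1/C=C/C(=O)OCC(C)C`, carries isobutoxy there and gives 1.43 h, while compound 3, `CCOc1cc(NC(=O)C2(NC(=O)c3ccc4c(C5CCCC5)c(-c5ncc(Cl)cn5)n(C)c4c3)CCC2)ccc1/C=C/C(=O)OCC(Cl)(Cl)Cl`, carries 2,2,2-trichloroethoxy and gives 1.75 h. Both steps point the same way: an at least 3.4-fold lower number from compound 1 to compound 2 (0.54 log units; beyond the scatter), and an at least 2.8-fold lower number from compound 1 to compound 3 (0.45 log units; beyond the scatter). Between the two oxygen-linked groups the difference is slight, a 1.2-fold higher number from compound 2 to compound 3 (0.09 log units; within the scatter).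

Compound 4, `CCOc1cc(NC(=O)C2(NC(=O)c3ccc4c(C5CCCC5)c(-c5ncc(Cl)cn5)n(C)c4c3)CCC2)ccc1/C=C/C(=O)OCC(N)=O`, has not been measured. It differs from compound 1 as follows: carbamoylmethoxy in place of (1-carbamoyl-2-carboxyethyl)amino on a carbonyl carbon. Since compound 4 carries carbamoylmethoxy on the carbonyl carbon, the same kind of exchange seen in compound 2 and compound 3, a step of the same sort is expected: an at least 3.3-fold lower number from compound 1 to compound 4 (0.52 log units; beyond the scatter). Compound 4 is therefore estimated at 1.5 h, most likely between 0.7 h and 3.5 h.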

Compound 4, half-life: 0.6 h
Beside the measured number, compound 4's estimate is 2.5-fold (0.40 log units) above it; the measured number lies below the stated range.
By their numbers in this assay, from the lowest: compound 4; then compounds 2 and 3 (each within the scatter of the next). At a limit, above all of these: compound 1.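

In this assay, the new result shows that the group on the saturated chain carbon bound to the oxygen can matter, which compound 2 and compound 3 could not show, as their values lie within the scatter of each other. Carbamoyl in that place gives a shorter life than either isopropyl (a 2.4-fold lower number from compound 2 to compound 4 (0.38 log units; beyond the scatter)) or trichloromethyl (a 2.9-fold lower number from compound 3 to compound 4 (0.46 log units; beyond the scatter)). Compound 1 also carries a carbamoyl group, yet the full exchange is large (an at least 8.3-fold lower number from compound 1 to compound 4 (0.92 log units; beyond the scatter)), so carbamoyl alone does not keep the number high.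

From the compounds shown here alone, it remains open whether a carboxylic acid on that chain carbon, or an isobutylamino group on the carbonyl carbon, would behave like the oxygen-linked groups or like compound 1. The true life of compound 1 also stays unknown, as its value is a limit and not a number: the limit of > 5 h in this assay, at which 1 of the 4 values shown sits.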